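Butyl to 3-Chlorophenyl on the Thiourea Nitrogen

The source may report more compounds than this note shows. Statements on the series, on what has been measured and on what is new or still open speak of the compounds shown alone.

Compound 1 `OC(c1ccccc1)c1cnc2scc(-c3ccc(Br)cc3)n12` gives 1090 nM in an assay on cells for inhibition of Indoleamine 2,3-dioxygenase 1 (Homo sapiens); a lower number here means a stronger inhibitor, a higher number a weaker inhibitor.
Compound 2 `CCCCNC(=S)NCc1cnc2scc(C#CC3CC3)n12` gives 502 nM in this assay.

Of the two compounds measured, compound 2 has the lower number in this assay; compound 1 gives the higher one, and the gap between them lies beyond the usual scatter of repeated runs. Compound 2 is therefore the stronger of the pair on the numbers shown.

Compound 3 `S=C(NCc1cnc2scc(C#CC3CC3)n12)Nc1cccc(Cl)c1` departs from compound 2 in one place: 3-chlorophenyl in place of butyl on an amide-type nitrogen. Everything else, the shared core with its cyclopropylethynyl substituent and the thiourea linker, is kept unchanged. Within the data shown here, no measured pair shows this kind of exchange, so no step can be read from the data, and the expectation rests on compound 2 alone and on the nature of the change.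

The estimate for compound 3 is a modest drop in the number in this assay, within or just beyond the scatter: a 1.7-fold lower number from compound 2 to compound 3 (0.22 log units; within the scatter) is the step expected. Compound 3 is expected to give 300 nM, with a range from 100 nM to 1000 nM.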

Compound 3, half-maximal inhibitory concentration: 27.6 nM
Estimate against measurement, compound 3: 11-fold (1.04 log units) above; the measured number lies below the stated range.
By their numbers in this assay, from the lowest: compound 3; then compound 2; then compound 1.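

The thiourea nitrogen of this series turns out to be highly sensitive to its substituent: in this assay, 3-chlorophenyl in place of butyl gives an 18-fold lower number from compound 2 to compound 3 (1.26 log units; beyond the scatter), a large step. Compound 1 and compound 2 differ in more than one place, so the earlier values could not isolate any single group, whereas this step holds the shared core, its cyclopropylethynyl substituent and the thiourea linker constant and assigns the whole change to this one exchange on the amide-type nitrogen. No measurement shown accounts for the size of this step, and its cause remains unknown.

Among these compounds, the single exchange replaces an open four-carbon chain with a six-membered aromatic ring that also carries chlorine, so the shares of the ring and of the chlorine in this step cannot be separated from these compounds. Plain phenyl would test the contribution of the chlorine on this nitrogen and cyclohexyl that of an aromatic ring, while a pyridyl ring or a methoxyphenyl group would show how far the step extends to other ring substituents.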